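Compound 3 to compound 4: hydroxy to methoxy

The source may hold more compounds than are shown below. What is called first, only, known or untested is meant among the compounds shown, and "the series" means these compounds.

Compound 1 `COc1ccc2[nH]c(-c3cc(OC)c(OC)c(OC)c3)cc2c1` has hydrogen on the aromatic nitrogen, where compound 2 `COc1ccc2c(c1)cc(-c1cc(OC)c(OC)c(OC)c1)n2Cc1ccc(OCc2ccccc2)cc1` and compound 3 `COc1ccc2c(c1)cc(-c1cc(OC)c(OC)c(OC)c1)n2Cc1ccc(O)cc1` carry benzyl-type groups. In a functional assay on MDA-MB-231 cells (Homo sapiens) for cytotoxicity, read by MTT assay, with a stated time of 24 h (on this read-out lower numbers stand for stronger inhibition and higher numbers for weaker inhibition), compound 1 gives > 30000 nM, which is a limit. In this assay compound 2 gives > 30000 nM, also a limit. Among the measured compounds shown here, compound 3 gives 17300 nM, the only actual number so far, and so the sole numerical anchor for the series.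

Compound 4 `COc1ccc(Cn2c(-c3cc(OC)c(OC)c(OC)c3)cc3cc(OC)ccc32)cc1` is still unmeasured. It differs from compound 3 by methyl in place of hydrogen on an oxygen on an aromatic ring, turning 4-hydroxybenzyl into 4-methoxybenzyl.

The same oxygen changes in the measured step of an at least 1.7-fold lower number from compound 2 to compound 3 (0.23 log units; that floor lies within the scatter), where hydrogen replaces benzyl. The step of an at least 1.7-fold lower number from compound 1 to compound 3 (0.23 log units; that floor lies within the scatter) concerns the whole 4-hydroxybenzyl group. Both rest on limits, and neither floor clears the scatter, so they give only a weak hint that compound 3 sits on the lower side. With methyl a smaller group than benzyl, compound 4 is expected to fall near compound 3 or somewhat higher. The expected move is a 1.4-fold higher number from compound 3 to compound 4 (0.16 log units; within the scatter), a small one towards weaker inhibition. For compound 4 the estimate is 25000 nM, with an expected range of 11000 nM to 60000 nM.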

Compound 4, half-maximal inhibitory concentration: > 30000 nM
Compound 4: no number, only a limit; the forecaster's own chance of this, stated with the estimate: 50%; at least 1.2-fold (0.07 log units) between middle value and limit.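

In this assay compound 4 gives > 30000 nM, which is a limit and not a number. Methyl in place of hydrogen on the oxygen of the 4-hydroxybenzyl group gives an at least 1.7-fold higher number from compound 3 to compound 4 (0.23 log units; that floor lies within the scatter); this is the first readable step in which only that hydrogen changes, and it points the same way as the earlier floors without clearing the scatter. The hydroxy form remains the only one in the series with an actual number, whereas capping that oxygen with methyl or with benzyl leaves only a limit, so the floor on this change cannot be sharpened from these data: the limit of > 30000 nM in this assay, at which 3 of the 4 values shown sit.

The steps to compound 4 from compound 1 and from compound 2 cannot be read, as both ends of each are limits. Still open, as far as these compounds go, is whether the number for the hydroxy form depends on that hydroxy group as such, or whether an amine or a carboxylic acid in its place on the benzyl group would give a measurable value in this assay.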